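Allyl in place of phenyl on the ring nitrogen

A few compounds are considered here, and "the series" means these few. Any claim that something is new, unique, unknown or untested is made for them only; others in the source may bear on it.

Measured so far in a functional assay on the whole organism (strain albino) for inhibition, with Rattus norvegicus as the target, read by paw edema, with stated times of 30 min and 1 h, at a dose of 0.28 mmol/kg by the oral route; on this read-out lower numbers stand for less inhibition and higher numbers for more inhibition at the one dose given (going by the name of the read-out):
compound 1 `C=CCn1c(SCC(=O)Nc2ccc(/C(C)=N/O)cc2)nnc1-c1ccccc1` gives 61%
compound 2 `C/C(=N\O)c1ccc(NC(=O)CSc2nnc(-c3ccccc3)n2-c2ccccc2)cc1` gives 50%
compound 3 `COc1cc(-c2nnc(SCC(=O)Nc3ccc(C(C)=O)cc3)n2-c2ccccc2)cc(OC)c1OC` gives 49%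

Compound 2 and compound 1 share a core and differ in one place, (allyl in place of phenyl on an aromatic nitrogen). This single change made a number 11 percentage points higher from compound 2 to compound 1 (beyond the scatter). Compound 3 rests on another core; the difference between the core of compound 3 and the core of compound 2 is not broken down here, and the values of compound 3 and compound 2 lie within the scatter of each other.

Compound 4 `C=CCn1c(SCC(=O)Nc2ccc(C(C)=O)cc2)nnc1-c1cc(OC)c(OC)c(OC)c1` has not been measured. It differs from compound 3 by allyl in place of phenyl on an aromatic nitrogen. This is the same kind of change as that from compound 2 to compound 1, not the same: here the ring nitrogen is next to the ring atom that bears a 3,4,5-trimethoxyphenyl group, whereas in the earlier pair it is next to the ring atom that bears a phenyl group (6 heavy atoms).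

Going by the values given here, for compound 4 in this assay a step of a number 10 percentage points higher from compound 3 to compound 4 (within the scatter) is expected, resting on one observation only, namely a number 11 percentage points higher from compound 2 to compound 1 (beyond the scatter), with no second pair to confirm that the change carries over to the other core. The estimate for compound 4 is 59%, expected to fall between 46% and 72%.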

Compound 4, a percentage reported as inhibition, in the whole organism at one dose (the size of the read-out at that dose, not a potency): 48%
Compound 4: the middle estimate sits 11 percentage points above what was measured, within the range that was stated.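

In this assay, allyl in place of phenyl on the aromatic nitrogen gives a number 1 percentage points lower from compound 3 to compound 4 (within the scatter) on this core, so the change brings no gain that can be read here. Set beside the earlier pair, the two steps cannot be told apart: the same change on two cores in this assay, a number 11 percentage points higher (beyond the scatter) from compound 2 to compound 1 and a number 1 percentage points lower (within the scatter) from compound 3 to compound 4, 12 percentage points apart, within the scatter of two such steps

The series therefore does not show that the change carries over from one core to the other, nor that its outcome depends on the core. Each core supplies a single pair at a single dose, and the two cores differ in more than one place, so no part of their difference can be tied to the result.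

Still open, on these data alone, is how a propyl or benzyl group on the same ring nitrogen would compare with allyl and phenyl on either core. Also open, as far as these compounds go, is whether allyl in place of phenyl gives a consistent step on further cores, such as one carrying a 3,4,5-trimethoxyphenyl group together with the oxime.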